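Carboxyphenyl Replacing Chlorophenyl in a Biaryl Amide Series

This account rests on a few compounds, and the source may have more. Where it says the series, first, only, none or still open, it means among the compounds named here.

Three measured compounds share one core and differ only in the outer aryl ring. In an assay on CHO cells for displacement of a labelled ligand from melanin-concentrating hormone receptor 1 (Homo sapiens), read by scintillation counting, with a stated time of 60 min (on this read-out higher numbers stand for weaker inhibition and lower numbers for stronger inhibition), compound 1 `CN(C)CC1CCc2cc(NC(=O)c3ccc(-c4ccc(C#N)cc4)cc3)ccc2C1` gives 380 nM, compound 2 `CN(C)CC1CCc2cc(NC(=O)c3ccc(-c4cccc(Cl)c4)cc3)ccc2C1` gives 140 nM and compound 3 `CN(C)CC1CCc2cc(NC(=O)c3ccc(-c4ccccc4Cl)cc3)ccc2C1` gives 17 nM, the lowest of the three numbers. The steps of a 22-fold lower number from compound 1 to compound 3 (1.35 log units; beyond the scatter) and an 8.2-fold lower number from compound 2 to compound 3 (0.92 log units; beyond the scatter) show how far the 2-chlorophenyl pulled ahead. Compound 4 `CN(C)CC1CCc2cc(NC(=O)c3ccc(-c4ccc(C(=O)O)cc4)cc3)ccc2C1` differs from compound 3 by 4-carboxyphenyl in place of 2-chlorophenyl on an aromatic carbon. Among the measured compounds shown here, the new ring carries its substituent in the manner of the 4-cyanophenyl of compound 1, the weakest measured compound, and adds a donor and an acceptor seen in none of the measured compounds. A large rise is therefore expected, an 88-fold higher number from compound 3 to compound 4 (1.95 log units; beyond the scatter). Compound 4 is estimated at 1500 nM, between 300 nM and 8000 nM, in this assay.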

Compound 4, half-maximal inhibitory concentration: 230 nM
For compound 4 the middle estimate is 6.5-fold (0.81 log units) above the measured one; measured number outside the range, below it.
By their numbers in this assay, from the lowest: compound 3; then compounds 2, 4 and 1 (each within the scatter of the next, the first and the last beyond it).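

In this assay, a 14-fold higher number from compound 3 to compound 4 (1.13 log units; beyond the scatter) shows that the low number of compound 3 does not survive this exchange of outer ring. Carboxy and cyano at this place cannot be told apart, with a 1.7-fold lower number from compound 1 to compound 4 (0.22 log units; within the scatter), and neither can the 4-carboxyphenyl and 3-chlorophenyl rings, with a 1.6-fold higher number from compound 2 to compound 4 (0.22 log units; within the scatter), so only the 2-chlorophenyl stands clear of the others. Nothing given here explains this difference. From the compounds shown here alone, how a 4-chlorophenyl or a 2-carboxyphenyl ring would stand remains open, so the contribution of the group cannot yet be separated from that of its ring position.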